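The source may report more compounds than this note shows. Statements on the series, on what has been measured and on what is new or still open speak of the compounds shown alone.

Measured compounds:
- compound 1 `CCOC(=O)c1cnn(CC(C)O)c1NC(=O)Nc1ccc(F)cc1`: 0.2 nM
- compound 2 `CCCC(O)Cn1ncc(C(=O)OCC)c1NC(=O)NCc1ccccc1`: 0.0032 nM
- compound 3 `CCCC(O)Cn1ncc(C(=O)OCC)c1NC(=O)NC(C)C`: 1 nM

In a functional assay on cells (Neutrophil, Homo sapiens) for inhibition, with a stated time of 10 min (on this read-out higher numbers stand for weaker inhibition and lower numbers for stronger inhibition), compound 3 gives the highest number of the three; compound 1 stands nearest to it and compound 2 furthest, both beyond the scatter. Among the compounds with values here, the only step between measured compounds that differ in one place, a 310-fold higher number from compound 2 to compound 3 (2.49 log units; beyond the scatter), concerns the group on the amide-type nitrogen, not the chain on the aromatic nitrogen, so no measured step bears directly on the move to compound 4.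

Compound 4 `CCOC(=O)c1cnn(C)c1NC(=O)NC(C)C` differs from compound 3 as follows: hydrogen in place of 1-hydroxybutyl on a saturated chain carbon bound to an aromatic nitrogen. Compounds 1 and 3 both carry a hydroxyl-bearing chain on the aromatic nitrogen and differ elsewhere as well, so their values say nothing clean about this position. Within the data shown here, with no anchoring step, the expectation for compound 4 is a modest weakening, a step of about a 3.0-fold higher number from compound 3 to compound 4 (0.48 log units; beyond the scatter), held with wide uncertainty because the change removes a hydrogen-bond donor and acceptor that every measured compound carries. Compound 4 is thus estimated at 3 nM, within a range of 0.3 nM to 30 nM.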

Compound 4, half-maximal inhibitory concentration: 0.0018 nM
Compound 4: middle estimate off by 1700-fold (3.22 log units), on the high side; the whole stated range lies above it.
By their numbers in this assay, from the lowest: compounds 4 and 2 (each within the scatter of the next); then compound 1; then compound 3.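

In this assay the change from 2-hydroxypentyl to methyl on the aromatic nitrogen gives a 560-fold lower number from compound 3 to compound 4 (2.74 log units; beyond the scatter), so the hydroxyl-bearing chain is not required for a low number with isopropyl on the amide-type nitrogen, and compound 4 is far stronger than compound 3. This position can therefore produce a large step, as the amide-type nitrogen already did with a 310-fold higher number from compound 2 to compound 3 (2.49 log units; beyond the scatter), so the two sites both matter in this series. Nothing available accounts for the size of the change at the aromatic nitrogen.

The compounds shown do not separate loss of the hydroxyl from shortening of the chain, which a plain pentyl chain or a 2-hydroxyethyl group would address. Also open, going by these compounds, is whether methyl keeps this effect alongside benzyl on the amide-type nitrogen, and how an ethyl group or an amine-bearing chain would compare.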